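The source may report more compounds than this note shows. Statements on the series, on what has been measured and on what is new or still open speak of the compounds shown alone.

Working notes on the series. In an ADME assay on MT4 cells (Homo sapiens) for cytotoxicity, read by MTT assay (on this read-out lower numbers stand for higher toxicity in this test and higher numbers for lower toxicity in this test), compound 1 `CC(C)C1C(=O)N(O)C(=O)c2ccccc21` gives 123000 nM, compound 3 `CC1C(=O)N(O)C(=O)c2ccccc21` gives 250000 nM, and compound 2 `O=C1c2ccccc2C(CCc2ccccc2)C(=O)N1O` gives 30000 nM, the lowest number of the three. The measured steps run a 2.0-fold higher number from compound 1 to compound 3 (0.31 log units; beyond the scatter) and an 8.3-fold higher number from compound 2 to compound 3 (0.92 log units; beyond the scatter): in both, a smaller group on the saturated ring carbon went with a higher number. Compound 4 `O=C1c2ccccc2C(CCCc2ccccc2)C(=O)N1O` is not yet measured; it differs from compound 2 by benzyl in place of phenyl on a saturated chain carbon, two bonds along the chain from a saturated ring carbon. The change enlarges the group rather than shrinking it, so a modest lowering is expected, in the direction opposite to an 8.3-fold higher number from compound 2 to compound 3 (0.92 log units; beyond the scatter). The expected step for compound 4 is a 1.5-fold lower number from compound 2 to compound 4 (0.18 log units; within the scatter). Compound 4 is estimated at 20000 nM, with a range from 8000 nM to 50000 nM.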

Compound 4, half-maximal cytotoxic concentration: 5200 nM
Estimate against measurement, compound 4: 3.8-fold (0.59 log units) above; measured number outside the range, below it.
By their numbers in this assay, from the lowest: compound 4; then compound 2; then compound 1; then compound 3.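

Adding to the chain at this position still moves the number, and in a direction the earlier steps did not cover: benzyl in place of phenyl, on a saturated chain carbon two bonds along the chain from a saturated ring carbon, gives a 5.8-fold lower number from compound 2 to compound 4 (0.76 log units; beyond the scatter) and is beyond the scatter. With an 8.3-fold higher number from compound 2 to compound 3 (0.92 log units; beyond the scatter) on the shorter side, compounds 3, 2 and 4 fall in one order, the number dropping as the group on the saturated ring carbon grows. Nothing at hand accounts for this step.

As far as these compounds go, whether a longer chain would lower the number further remains open. So does the effect of an amine or a carboxylic acid at the end of the chain.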